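Lengthening the Chain on Compound 1

The compounds below may be only part of what the source reports. "The series", "measured", "known", "first", "only" and "open" are said of these compounds alone.

Compound 1, `CCc1nnc2c(C#N)c(N3CCC(c4ccccc4)CC3)ccn12`, is one of two compounds with numbers in a functional assay on CHO cells for positive allosteric modulation of metabotropic glutamate receptor 2 (Homo sapiens), read by GTPgammaS binding, with a stated time of 30 min; a higher number here means that more compound is needed for the effect, a lower number that less compound is needed. In this assay compound 1 gives 696 nM, the higher of the two. Compound 2, `CCCc1cnc2c(C#N)c(N3CCC(c4ccccc4)CC3)ccn12`, gives 155 nM in this assay; it differs from compound 1 in more than one place, so its lower number cannot be tied to any single change. Compound 3, `CCCc1nnc2c(C#N)c(N3CCC(c4ccccc4)CC3)ccn12`, has not been measured. It differs from compound 1 by one change: methyl in place of hydrogen on a saturated chain carbon, two bonds along the chain from an aromatic carbon, so the ethyl of compound 1 becomes propyl. Going by the values given here, no measured pair shows this change on its own. Compound 2 carries propyl and gives 155 nM, which hints at a lower number. The step from compound 1 to compound 3 is therefore expected to be modest, toward a lower number, at about a 2.0-fold lower number from compound 1 to compound 3 (0.30 log units; within the scatter). Compound 3 is estimated at 350 nM, ranging from 150 nM to 900 nM.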

Compound 3, half-maximal effective concentration: 299 nM
Estimate against measurement, compound 3: 1.2-fold (0.07 log units) above, within the range that was stated.
By their numbers in this assay, from the lowest: compounds 2 and 3 (each within the scatter of the next); then compound 1.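

In this assay, the change from ethyl to propyl, seen here on its own, gives a 2.3-fold lower number from compound 1 to compound 3 (0.37 log units; beyond the scatter). A single added methyl on a saturated chain carbon, two bonds along the chain from an aromatic carbon, is thus enough to move the number beyond the usual scatter, something compound 2 could not show, as it differs from compound 1 in more than one place. Nothing available explains why this added methyl goes with a lower number.

As far as these compounds go, one step does not make a trend, so it remains open whether a longer chain such as butyl would lower the number further or raise it again. Also open, from the compounds shown here alone, is how a branched chain such as isopropyl, or a chain carrying an ether oxygen such as methoxymethyl, would fare at this position.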